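The source may hold more compounds than are shown below. What is called first, only, known or untested is meant among the compounds shown, and "the series" means these compounds.

In a functional assay on NCI-H1975 cells (Homo sapiens) for antiproliferative activity (on this read-out lower numbers stand for stronger inhibition and higher numbers for weaker inhibition), compound 1 (`Cc1c2c(n3c1CCCN[C@@H](C)[C@H](C)Nc1cc-3ccc1C(N)=O)CC(C)(C)CC2=O`) gives 20 nM and compound 2 (`COCCC(=O)N1CCc2c(C)c3c(n2-c2ccc(C(N)=O)c(c2)N[C@@H](C)[C@H](C)C1)CC(C)(C)CC3=O`) gives 31 nM as its value, and these two numbers lie within the usual scatter of each other. Compound 3 (`Cc1c2c(n3c1CCN(C(=O)[C@H](C)O)C[C@@H](C)[C@H](C)Nc1cc-3ccc1C(N)=O)CC(C)(C)CC2=O`) differs from compound 2 in one group (1-hydroxyethyl in place of 2-methoxyethyl on a carbonyl carbon): it carries 1-hydroxyethyl in place of 2-methoxyethyl on a carbonyl carbon. Among the compounds with values here, no measured pair shows this change, and the only guide is compound 2 at 31 nM here, so no step beyond the scatter is expected in this assay for this swap. For compound 3 the estimated value is 30 nM with an expected range from 12 nM to 75 nM in this measurement.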

Compound 3, half-maximal inhibitory concentration: 52 nM
Estimate against measurement, compound 3: 1.7-fold (0.24 log units) below; the measured number falls inside the stated range.
By their numbers in this assay, from the lowest: compounds 1, 2 and 3 (each within the scatter of the next, the first and the last beyond it).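

In this assay putting 1-hydroxyethyl in place of 2-methoxyethyl on a carbonyl carbon gives a 1.7-fold higher number from compound 2 to compound 3 (0.22 log units; within the scatter) and so shows that this position tolerates a group with a hydrogen-bond donor and a defined stereocentre, with no step beyond the scatter. Still open, going by these compounds, is whether an amine, a carboxylic acid or a longer chain at this position would move the number beyond the scatter, and what the mirror-image form of 1-hydroxyethyl would do. No further measurement shown here bears on this result.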